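This account rests on a few compounds, and the source may have more. Where it says the series, first, only, none or still open, it means among the compounds named here.

Measured compounds in a functional assay on SW480 cells (Homo sapiens) for cytotoxicity, read by MTT assay, with a stated time of 4 days; on this read-out lower numbers stand for stronger inhibition and higher numbers for weaker inhibition:
- compound 1, `C=C1C[C@]23C[C@@]1(O)CC[C@H]2c1ccc(OS(=O)(=O)c2ccc(C)cc2)c(C)c1[C@@H]3Cn1cc(-c2ccc(Cl)cc2)nn1`: compound 1 gives > 20000 nM, which is a limit of this assay and not a number.
- compound 2, `Cc1c(O)ccc2c1[C@H](Cn1cc(-c3ccc(F)cc3)nn1)[C@@]13CC(=O)[C@@](C)(CC[C@@H]21)C3`: compound 2 gives > 20000 nM, again a limit rather than a number.
- compound 3, `C=C1C(=O)[C@]23C[C@@]1(O)CC[C@H]2c1ccc(O)c(C)c1[C@@H]3Cn1cc(-c2ccccc2)nn1`: compound 3 gives 260 nM.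

Going by the values given here, compound 3 thus holds the only number so far in this assay; the other two results sit at the limit of > 20000 nM in this assay, at which 2 of the 3 values shown sit. Among the compounds with values here, no pair of measured compounds differs in one place only, so no measured step is available; compound 1 and compound 3 differ in several places at once, and their values show only that one sits at a limit and the other at a number.

Compound 4, `C=C1C(=O)[C@]23C[C@@]1(O)CC[C@H]2c1ccc(O)c(C)c1[C@@H]3Cn1cc(-c2ccc(Cl)cc2)nn1`, follows from compound 3 by chloro in place of hydrogen on an aromatic carbon; the same difference, cut one bond further out, reads phenyl to 4-chlorophenyl. The rest of the structure, including the exocyclic methylene, the ketone and the free phenol, is kept. With nothing measured on this change in the series, the expected step is none beyond the usual scatter, in either direction. The estimate for compound 4 in this assay is therefore 300 nM, within 100 nM to 900 nM, a step of a 1.2-fold higher number from compound 3 to compound 4 (0.06 log units; within the scatter) that is expected to stay close to compound 3.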

Compound 4, half-maximal inhibitory concentration: 280 nM
The estimate for compound 4 lay 1.1-fold (0.03 log units) above the measured number, within the range that was stated.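

In this assay the series now holds its first measured step: phenyl to 4-chlorophenyl gives a 1.1-fold higher number from compound 3 to compound 4 (0.03 log units; within the scatter), so on this read-out chloro in place of hydrogen, para to a large group, cannot be told apart from the parent compound. Going by these compounds alone, this position therefore accepts one chlorine atom with the exocyclic methylene, the ketone and the free phenol all kept, which the earlier compounds, differing in several places at once, could not show. Nothing measured here bears on a cause for this step.

As far as these compounds go, whether this holds beyond chloro stays open: an amine, a carboxylic acid, a methoxy group or a longer chain at the same position would test it, and fluoro appears only in compound 2, which differs from compound 3 in several other places. Within the data shown here, the ketone, the exocyclic methylene and the free phenol have no single-place step of their own, so which of these parts separates compound 3 from the limit results of compound 1 and compound 2 remains unresolved.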